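The compounds below may be only part of what the source reports. "The series", "measured", "known", "first", "only" and "open" are said of these compounds alone.

Compounds measured in a functional assay on Hs-578T cells (Homo sapiens) for inhibition, read by sulforhodamine B assay, with a stated time of 48 h; on this read-out lower numbers stand for stronger inhibition of growth and higher numbers for weaker inhibition of growth:
- compound 1 `COc1ccc(-c2[nH]c3ccccc3c2/C=C(\C#N)S(=O)(=O)c2ccccc2)cc1`: 682 nM
- compound 2 `CCOC(=O)C(=Cc1c(-c2ccccc2)[nH]c2ccccc12)C(=O)OCC`: 3800 nM

Of these two numbers, compound 1 has the lower one; compound 2, its nearest neighbour, sits at a value that is a good deal higher, and that gap lies beyond the scatter. For the measured compounds named here, no step between two measured compounds that differ in only one place is available, so the two values show only that compound 1 is the more potent of the pair.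

The step followed here leads from compound 1 to compound 3 `COc1ccc(-c2[nH]c3ccc(OC)cc3c2/C=C(\C#N)S(=O)(=O)c2ccccc2)cc1`, which is not yet measured. The change is methoxy in place of hydrogen on an aromatic carbon. Going by the values given here, with no comparable step in hand, the expectation for compound 3 is a small change, if any, within the usual scatter, with the number perhaps a little lower. Compound 3 is thus expected to give about 500 nM, in a range from 150 nM to 1800 nM. This estimate implies a step of a 1.4-fold lower number from compound 1 to compound 3 (0.13 log units; within the scatter).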

Compound 3, concentration for 50% growth inhibition: 538 nM
The estimate for compound 3 lay 1.1-fold (0.03 log units) below the measured number; measured number inside the range.
By their numbers in this assay, from the lowest: compounds 3 and 1 (each within the scatter of the next); then compound 2.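

this assay now gives the first step that differs in one place, a 1.3-fold lower number from compound 1 to compound 3 (0.10 log units; within the scatter), so methoxy in place of hydrogen on this aromatic carbon, meta to a fused ring and para to a fused ring, leaves compound 1 and compound 3 indistinguishable on this read-out. The earlier pair could not show this, since compound 1 and compound 2 differ in more than one place, and it means that this carbon of the core can carry methoxy with no shift beyond the scatter. Nothing available accounts for this outcome or links it to any property of the group.

From the compounds shown here alone, it remains open whether an amine, a carboxylic acid or a longer chain such as butoxy on this same carbon would also stay within the scatter. Equally open, going by these compounds, is how methoxy would read on the other carbons of this ring.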